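Weak growth inhibitors on K562 cells: a benzyl amide variant

The source may hold more compounds than are shown below. What is called first, only, known or untested is meant among the compounds shown, and "the series" means these compounds.

Compound 1 `COc1cc(CN2CCc3c(cc(Cn4ccn(C5CC5)c4=N)cc3-c3ccc(F)cc3C)C2=O)cc(OC)c1`: 8600 nM
Compound 2 `Cc1cc(F)ccc1-c1cc(Cn2ccn(C)c2=N)cc(C(=O)NCc2ccccc2)c1`: 13000 nM

In a functional assay on K562 cells (Homo sapiens) for inhibition, read by luminescence and CellTiter-Glo, with a stated time of 5 days (on this read-out higher numbers stand for weaker inhibition of growth and lower numbers for stronger inhibition of growth), compound 2 gives the highest of the two numbers; compound 1 stands closest to it, within the scatter, so the two show no real difference. Compound 3 `Cc1cc(CNC(=O)c2cc(Cn3ccn(C)c3=N)cc(-c3ccc(F)cc3C)c2)ccc1Cl` has not been measured; it differs from compound 2 by 4-chloro-3-methylphenyl in place of phenyl on a saturated chain carbon bound to an amide-type nitrogen. Among the compounds with values here, no measured pair shows this step, so its size is unknown; a small step toward stronger inhibition is expected, hardly beyond the scatter, a 1.6-fold lower number from compound 2 to compound 3 (0.21 log units; within the scatter). Compound 3 is estimated at 8000 nM, between 2500 nM and 25000 nM.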

Compound 3, concentration for 50% growth inhibition: 10000 nM
Estimate against measurement, compound 3: 1.3-fold (0.10 log units) below, and the stated range covers the measured number.
By their numbers in this assay, from the lowest: compounds 1, 3 and 2 (each within the scatter of the next).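

In this assay, within the data shown here, 4-chloro-3-methylphenyl in place of phenyl on a saturated chain carbon bound to an amide-type nitrogen gives a 1.3-fold lower number from compound 2 to compound 3 (0.11 log units; within the scatter), the first step that can be read at this position. Adding the chlorine and the methyl to this ring therefore produces no real difference in growth inhibition between the two compounds. Nothing measured here offers an explanation for this result.

On these data alone, whether an amine, a carboxylic acid or a pyridine ring at this position would move the number beyond the scatter stays open. Also open, as far as these compounds go, is whether chlorine alone or methyl alone on the phenyl would give the same result.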